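Removing a Chloro Group from a Weakly Cytotoxic Chromone

A few compounds are considered here, and "the series" means these few. Any claim that something is new, unique, unknown or untested is made for them only; others in the source may bear on it.

Compound 1 `Cc1cc(C)nc(SCc2cc(=O)c3cc(Cl)ccc3o2)n1` was tested in a functional assay on HEp-2 cells (Homo sapiens) for cytotoxicity, read by MTT assay, with a stated time of 72 h; on this read-out lower numbers stand for stronger inhibition and higher numbers for weaker inhibition. In this assay compound 1 gives > 25000 nM, which is a limit of the assay rather than a measured number. Of the two values shown, (the limit of > 25000 nM in this assay, at which 1 of the 2 values shown sits), and that is where compound 1 stands. Compound 2 `Cc1cc(C)n2nc(SCc3nnc(SCc4coc5ccccc5c4=O)n3-c3ccccc3)nc2n1` was measured in the same assay, and in this assay compound 2 gives 22100 nM. Compound 3 `Cc1cc(C)nc(SCc2cc(=O)c3ccccc3o2)n1` is the unmeasured partner of compound 1; the change is hydrogen in place of chloro on an aromatic carbon. For the measured compounds named here, no step between measured compounds is known here, so any expectation for compound 3 rests on the change alone. The step that the limit leaves unreadable from compound 1 to compound 3 is expected to stay within the scatter, in no particular direction. For compound 3 the expected value in this assay is 30000 nM, within a range of 10000 nM to 100000 nM, and a limit rather than a number is again likely.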

Compound 3, half-maximal inhibitory concentration: > 25000 nM
Compound 3: only a limit was reported; the forecaster's own chance of this, stated with the estimate: 70%; the middle value lies beyond the limit too.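

Compound 1 and compound 3 each give only a limit of the assay rather than a number, so no step between them can be read: the limit of > 25000 nM in this assay, at which 2 of the 3 values shown sit.

The compounds shown leave open whether hydrogen in place of chloro on an aromatic carbon changes the result in this assay at all.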